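The compounds below may be only part of what the source reports. "The series", "measured", "known", "first", "only" and "open" are said of these compounds alone.

Compounds measured in an assay on HEK293 cells for agonist activity at transient receptor potential cation channel subfamily M member 8 (Homo sapiens), read by fluorescence and calcium flux, with a stated time of 5 min; a higher number here means that more compound is needed for the effect, a lower number that less compound is needed:

Compound 1, `C=CCc1cc(OC)c(OC(C)C(OCC(C)C)c2ccc(O)c(OC)c2)c(OC)c1`, gives 138 nM.
Compound 2, `C=CCc1cc(OC)c(OC(C)C(OCC)c2ccc(O)c(OC)c2)c(OC)c1`, gives 332 nM.
Compound 3, `C=CCc1cc(OC)c(OC(C)C(O[C@@H]2C[C@H](C)CC[C@H]2C(C)C)c2ccc(O)c(OC)c2)c(OC)c1`, gives 28 nM.

Compound 3 has the lowest number of the three; the nearest to it is compound 1, a step away by a 4.9-fold lower number from compound 1 to compound 3 (0.69 log units; beyond the scatter), and the furthest is compound 2, separated by a 12-fold lower number from compound 2 to compound 3 (1.07 log units; beyond the scatter). Both steps replaced a small open chain on the oxygen on a saturated carbon with the 2-isopropyl-5-methylcyclohexyl group, and both lie beyond the scatter. The smaller step between the open chains, a 2.4-fold higher number from compound 1 to compound 2 (0.38 log units; beyond the scatter), is modest.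

Compound 4, `C=CCc1cc(OC)c(OC(C)C(O[C@H]2C[C@@H](C)CC[C@@H]2C(C)C)c2ccc(O)c(OC)c2)c(OC)c1`, keeps every atom and bond of compound 3: the two compounds have the same atoms and bonds; at least one stereo element is drawn with a configuration in one of them and without one in the other: 3 of 5 stereo elements differ; a stereocentre at a saturated ring carbon is drawn R in compound 3 and S in compound 4; a stereocentre at a saturated ring carbon is drawn R in compound 3 and S in compound 4; a stereocentre at a saturated ring carbon is drawn S in compound 3 and R in compound 4. For the measured compounds named here, none of the measured steps touches a stereocentre, so nothing measured bears directly on this change; the steps into compound 3 show only that the ring group matters for the number. With no measured guide for the inverted ring configuration, the expected step of a 2.5-fold higher number from compound 3 to compound 4 (0.40 log units; beyond the scatter) in this assay is a higher number of uncertain size, given wide bounds. The estimate for compound 4 in this assay is 70 nM, with a range from 20 nM to 250 nM.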

Compound 4, half-maximal effective concentration: 11 nM
Compound 4: the middle estimate sits 6.4-fold (0.80 log units) above what was measured; the measured number lies below the stated range.
By their numbers in this assay, from the lowest: compound 4; then compound 3; then compound 1; then compound 2.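

In this assay, for the compounds shown here, the configuration of the 2-isopropyl-5-methylcyclohexyl group itself shifts the number, with a 2.5-fold lower number from compound 3 to compound 4 (0.41 log units; beyond the scatter), although no atom or bond changes; the earlier compounds showed only that this ring group gave lower numbers than the open chains. With the configuration of compound 4, the ring group stands well clear of both open chains, with a 13-fold lower number from compound 1 to compound 4 (1.10 log units; beyond the scatter) and a 30-fold lower number from compound 2 to compound 4 (1.48 log units; beyond the scatter), so the step from the isobutyl compound is now large, whereas a 4.9-fold lower number from compound 1 to compound 3 (0.69 log units; beyond the scatter) was modest. The step between the two ring compounds cannot be read as a clean comparison of two fully defined forms, and one fact limits what it says about configuration: the fact that one of compounds 3 and 4 is drawn with a defined configuration and the other without, at the place where they differ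

The compounds shown leave open which of the three differing ring stereocentres carries the step, or whether it takes all of them together. They also leave open how an unsubstituted cyclohexyl or a longer chain such as hexyl on the same oxygen would compare with the 2-isopropyl-5-methylcyclohexyl group.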